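The compounds below may be only part of what the source reports. "The series", "measured", "known", "first", "only" and "open" are said of these compounds alone.

Measured compounds:

Compound 1 `O=C(/N=C/c1ccc(F)cc1)Nc1ccc2c(c1)C(=O)C(=O)N2CN1CCCCC1`: in a functional assay on the whole organism (strain Swiss albino) with Mus musculus as the target, with a stated time of 0.5 h (on this read-out higher numbers stand for an effect only at larger amounts of compound and lower numbers for an effect already at smaller amounts), compound 1 gives 100 mg/kg.
Compound 2 `O=C(/N=C/c1ccc([N+](=O)[O-])cc1)Nc1ccc2c(c1)C(=O)C(=O)N2CN1CCCCC1`: in this assay compound 2 gives 30 mg/kg.
Compound 3 `O=C(/N=C/c1ccc(Br)cc1)Nc1ccc2c(c1)C(=O)C(=O)N2CN1CCCCC1`: in this assay compound 3 gives 30 mg/kg.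

All three share one core and differ only in the group on the aromatic carbon of the pendant ring. Compound 3 stands level with compound 2: no change at the digits printed from compound 2 to compound 3 (within the scatter). Both sit at the lowest number of the three, and compound 3 is separated from compound 1 by a 3.3-fold lower number from compound 1 to compound 3 (0.52 log units; beyond the scatter).

Compound 4 `O=C(/N=C/c1ccc(O)cc1)Nc1ccc2c(c1)C(=O)C(=O)N2CN1CCCCC1` is not yet measured. It differs from compound 3 in one place: hydroxy in place of bromo on an aromatic carbon.

For the measured compounds named here, no measured step involves hydroxy, so the step from compound 3 to compound 4 has no direct precedent. The two steps that do bear on it, a 3.3-fold lower number from compound 1 to compound 2 (0.52 log units; beyond the scatter) and a 3.3-fold lower number from compound 1 to compound 3 (0.52 log units; beyond the scatter), show that exchanging the group at this one place can move the number modestly, and that fluoro there gave the highest number. Compound 4 is therefore expected to land between the measured extremes, with a step of a 2.0-fold higher number from compound 3 to compound 4 (0.30 log units; within the scatter) as the estimate. For compound 4 the expected value in this assay is 60 mg/kg, with a range from 30 mg/kg to 200 mg/kg.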

Compound 4, minimum effective dose: 300 mg/kg
Estimate against measurement, compound 4: 5.0-fold (0.70 log units) below; the whole stated range lies below it.
By their numbers in this assay, from the lowest: compounds 2 and 3 (each within the scatter of the next); then compound 1; then compound 4.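

Hydroxy on this carbon shows that the number in this assay can rise here as well as fall: a 10-fold higher number from compound 3 to compound 4 (1.00 log units; beyond the scatter) and a 10-fold higher number from compound 2 to compound 4 (1.00 log units; beyond the scatter) are the largest steps seen at this position. Fluoro no longer marks the top of the series, given a 3.0-fold higher number from compound 1 to compound 4 (0.48 log units; beyond the scatter) in the same direction. Bromo and hydroxy each count one heavy atom, so an exchange that leaves this count unchanged is enough for a step of this size.

Whether the rise belongs to hydroxy alone stays open, since methoxy, an amine or a carboxylic acid on the same carbon do not appear among these compounds. Nothing available here explains why hydroxy gives so much higher a number than bromo or nitro.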